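This account rests on a few compounds, and the source may have more. Where it says the series, first, only, none or still open, it means among the compounds named here.

Compound 2 `COc1ccc(C(=O)c2ccc3c(c2)C(n2ccccc2=O)=CC(C)(C)O3)cc1` gives 5.72 in a functional assay (trachea) with Rattus norvegicus as the target (a lower number here means a less potent compound, a higher number a more potent compound, by a factor of ten per unit of this negative logarithm), the lowest of the three numbers at hand, though compound 1 `COc1ccc2c(c1)C(n1ccccc1=O)=CC(C)(C)O2`, which gives 5.99, lies within the scatter of it. Compound 3 `CC1(C)C=C(n2ccccc2=O)c2cc(C(=O)c3ccc([N+](=O)[O-])cc3)ccc2O1` gives 6.09. Among the measured compounds shown here, the single measured step at the carbonyl-linked ring, a number 0.37 log units higher from compound 2 to compound 3 (beyond the scatter), is the only one that bears on compound 4 `CC1(C)C=C(n2ccccc2=O)c2cc(C(=O)c3ccccc3F)ccc2O1`, whose change from compound 2 is 2-fluorophenyl in place of 4-methoxyphenyl on a carbonyl carbon. For the measured compounds named here, that step was modest and there is no measured example of 2-fluorophenyl at this place. Compound 4 is expected to move by about a number 0.18 log units higher from compound 2 to compound 4 (within the scatter), a step that may not exceed the scatter, because a number 0.37 log units higher from compound 2 to compound 3 (beyond the scatter) was itself small. Compound 4 is therefore estimated at 5.9, in the range 5.5 to 6.3.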

Compound 4, logarithm of the reciprocal of the active concentration, log(1/C): 6.34
Beside the measured number, compound 4's estimate is 0.44 log units below it; measured number outside the range, above it.
By their numbers in this assay, from the lowest: compounds 2, 1, 3 and 4 (each within the scatter of the next, the first and the last beyond it).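

In this assay the step of a number 0.62 log units higher from compound 2 to compound 4 (beyond the scatter) shows that 2-fluorophenyl on this carbonyl carbon also gives a gain over 4-methoxyphenyl, so the gain seen with compound 3 is not unique to a nitro group. The step of a number 0.25 log units higher from compound 3 to compound 4 (within the scatter) leaves 2-fluorophenyl and 4-nitrophenyl unseparated, while the step of a number 0.35 log units higher from compound 1 to compound 4 (beyond the scatter) shows that (2-fluorophenyl)carbonyl can outdo methoxy on this aromatic carbon. Nothing measured here explains these differences. From the compounds shown here alone, what 4-fluorophenyl, plain phenyl or an aminophenyl would give on this carbonyl carbon stays open.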